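The source may report more compounds than this note shows. Statements on the series, on what has been measured and on what is new or still open speak of the compounds shown alone.

Compound 1, `Cc1nc(N)sc1CCCN/C(N)=N/C(=O)NC(C)c1ccc(Br)cc1`, gives 55 nM in a functional assay on Right cardiac atrium for agonist activity at histamine H2 receptor (Cavia porcellus), with a stated time of 30 min, in the presence of a further agent that is not named here; on this read-out lower numbers stand for an effect already at smaller amounts and higher numbers for an effect only at larger amounts of compound. Compound 2, `Cc1ccc(C(C)NC(=O)/N=C(\N)NCCCc2sc(N)nc2C)cc1`, gives 22.4 nM in the same assay.

Compound 2 has the lower of the two numbers, set apart from compound 1 by a 2.5-fold lower number from compound 1 to compound 2 (0.39 log units; beyond the scatter). Compound 3, `Cc1nc(N)sc1CCCN/C(N)=N/C(=O)NC(C)c1ccc(F)cc1`, differs from compound 2 by fluoro in place of methyl on an aromatic carbon. Among the compounds with values here, the one measured step that bears on this, a halogen exchanged for methyl, was modest; a return to a halogen, here a smaller one, is therefore expected to move the number back toward that of compound 1, by about a 1.8-fold higher number from compound 2 to compound 3 (0.25 log units; within the scatter). Compound 3 is expected to give 40 nM, between 15 nM and 110 nM.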

Compound 3, half-maximal effective concentration: 23.4 nM
Beside the measured number, compound 3's estimate is 1.7-fold (0.23 log units) above it, within the range that was stated.
By their numbers in this assay, from the lowest: compounds 2 and 3 (each within the scatter of the next); then compound 1.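

In this assay the exchange of methyl for fluoro gives a 1.0-fold higher number from compound 2 to compound 3 (0.02 log units; within the scatter) and so leaves the number in place, while the exchange of bromo for fluoro gives a 2.4-fold lower number from compound 1 to compound 3 (0.37 log units; beyond the scatter) and stays beyond the scatter. At this position, then, the halogens do not behave as one group: fluoro reads like methyl, and bromo, in compound 1, stands apart. Nothing measured here explains this difference.

As far as these compounds go, whether chloro or an unsubstituted phenyl would read like fluoro or like bromo stays open. So does the effect of a larger group such as methoxy or trifluoromethyl at this place.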